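A Hydroxy-to-Chloro Swap on an Alkynyl Chain

The source may hold more compounds than are shown below. What is called first, only, known or untested is meant among the compounds shown, and "the series" means these compounds.

Three compounds built on a shared quinoline-free description — call it the core of compound 1 — have been tested in a functional assay on P388 cells (Mus musculus) for antiproliferative activity, with a stated time of 72 h; on this read-out higher numbers stand for weaker inhibition and lower numbers for stronger inhibition. Compound 1, `CSc1cnc2ccccc2c1SCC#CCO`, gives 3.1 ug/mL in this assay, the lowest of the three numbers and therefore the strongest inhibition seen so far. Compound 2, `ClCC#CCSc1cnc2ccccc2c1Cl`, gives 13.4 ug/mL, a higher number that lies beyond the usual scatter when set against compound 1. Compound 3, `O=C(/C=C/c1ccccc1)OCC#CCSc1cnc2ccccc2c1Cl`, gives 32.8 ug/mL, higher still and again beyond the scatter. Compounds 2 and 3 each differ from compound 1 in more than one place, so their values are read only as they stand, without tracing any single change.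

Compound 4, `CSc1cnc2ccccc2c1SCC#CCCl`, has not yet been tested. It differs from compound 1 in one place: chloro in place of hydroxy on a saturated chain carbon bound to a triple-bonded carbon. The two measured neighbours do not isolate this exchange, so the size of its effect in this assay is open. The nearest comparison, compound 2 with a chloro at the chain end, gave 13.4 ug/mL, but it also carries a changed core. On this basis compound 4 is expected to show a modest weakening, a step of a 1.6-fold higher number from compound 1 to compound 4 (0.21 log units; within the scatter), or none beyond the scatter. The estimated value for compound 4 is 5 ug/mL, within a range from 1.5 ug/mL to 15 ug/mL.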

Compound 4, concentration for 50% inhibition: 2.7 ug/mL
For compound 4 the middle estimate is 1.9-fold (0.27 log units) above the measured one, and the stated range covers the measured number.
By their numbers in this assay, from the lowest: compounds 4 and 1 (each within the scatter of the next); then compound 2; then compound 3.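

In this assay, turning the 4-hydroxybut-2-yn-1-yl chain into the 4-chlorobut-2-yn-1-yl chain gives a 1.1-fold lower number from compound 1 to compound 4 (0.06 log units; within the scatter), so the two compounds cannot be told apart on this read-out. Among these compounds, this is the first direct look at this position, and it shows that the hydroxy, with 1 hydrogen-bond donor and 1 hydrogen-bond acceptor, can give way to a chloro, with 0 of each, without a change beyond the scatter; on the core of compound 1, the hydroxy is therefore not needed to keep this level of inhibition. No measurement shown here explains why the exchange leaves the number within the scatter.

On these data alone, with only hydroxy and chloro to compare at this position, it remains open how the chain end would respond to an amine, a methoxy group, a carboxylic acid or a longer chain in their place. As far as these compounds go, it also remains open whether the same exchange would read the same way on a different core, since the other two compounds differ from compound 1 in more than one place.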